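Notes on replacing furan-2-yl in compound 2

The source may hold more compounds than are shown below. What is called first, only, known or untested is meant among the compounds shown, and "the series" means these compounds.

Values in a functional assay on G-361 cells (Homo sapiens) for inhibition, with a stated time of 72 h; a lower number here means a stronger inhibitor, a higher number a weaker inhibitor
compound 1 `NC1CCC(Nc2nc(NCc3ccc(-n4cccn4)cc3)c3ncn(C4CCCC4)c3n2)CC1` gives 220 nM
compound 2 `NC1CCC(Nc2nc(NCc3ccc(-c4ccco4)nc3)c3ncn(C4CCCC4)c3n2)CC1` gives 97 nM
compound 3 `CC(C)(O)CNc1nc(NCc2ccc(-c3ccco3)nc2)c2ncn(C3CCCC3)c2n1` gives 2100 nM

Compound 2 holds the lowest of the three numbers. Compound 4 `NC1CCC(Nc2nc(NCc3ccc(-c4ccccc4O)nc3)c3ncn(C4CCCC4)c3n2)CC1` carries 2-hydroxyphenyl in place of furan-2-yl on an aromatic carbon, next to the ring nitrogen (2-hydroxyphenyl in place of furan-2-yl on an aromatic carbon). The closest measured change is modest, a 2.3-fold lower number from compound 1 to compound 2 (0.36 log units; beyond the scatter), and also involves the group carrying furan-2-yl. The large 22-fold higher number from compound 2 to compound 3 (1.34 log units; beyond the scatter) removes 4-aminocyclohexyl, which compound 4 keeps, so it bears little here. Within the data shown here, no measured compound carries 2-hydroxyphenyl, so no clear direction can be expected in this assay, and a change beyond the scatter is not expected. The expected change is a 1.2-fold higher number from compound 2 to compound 4 (0.09 log units; within the scatter). Compound 4 is estimated at 120 nM, with an expected range of 35 nM to 400 nM.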

Compound 4, half-maximal inhibitory concentration: 24 nM
Compound 4: the middle estimate sits 5.0-fold (0.70 log units) above what was measured; the measured number lies below the stated range.
By their numbers in this assay, from the lowest: compound 4; then compound 2; then compound 1; then compound 3.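

In this assay, 2-hydroxyphenyl in place of furan-2-yl gives a 4.0-fold lower number from compound 2 to compound 4 (0.61 log units; beyond the scatter) and shows that this aromatic carbon, next to the ring nitrogen, accepts a larger aryl group with a gain in the number. The change brings both a six-membered aromatic ring of carbon only and a hydrogen-bond donor, and this single step cannot separate the two. No evidence on hand accounts for the gain. Still open, on these data alone, is whether the hydroxyl is needed: plain phenyl, 2-methoxyphenyl or 2-aminophenyl would separate its contribution from that of the ring.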